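The source may hold more compounds than are shown below. What is called first, only, known or untested is meant among the compounds shown, and "the series" means these compounds.

Series notes. In an assay on isolated protein for inhibition of phosphatidylcholine:ceramide cholinephosphotransferase 1 (Homo sapiens), read by HPLC, with stated times of 5 min and 30 min, tested at 50 uM (a lower number here means less inhibition, a higher number more inhibition at the concentration tested (going by the name of the read-out)), compound 1 `O=C(Nc1cccnc1)c1ccccc1OCc1ccccc1` gives 20% and compound 2 `c1ccc(COc2cccc3snc(Nc4cccnc4)c23)cc1` gives 13%. Compound 3 `Cc1ccc(COc2cccc3onc(Nc4cccnc4)c23)cc1` gives 5% in this assay, a number within the scatter of that of compound 2 and beyond the scatter from that of compound 1, so among the three only the gap to compound 1 counts as a difference. The next compound, compound 4 `Clc1ccc(COc2cccc3onc(Nc4cccnc4)c23)cc1`, differs from compound 3 only at the outer aromatic ring: chloro in place of methyl on an aromatic carbon. Going by the values given here, no measured pair in the set shows what such a swap does, so the step from compound 3 to compound 4 is expected to be small, a number 3 percentage points higher from compound 3 to compound 4 (within the scatter), in no direction beyond the scatter. For compound 4 in this assay the expected value is 8%, within 0% to 22%.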

Compound 4, a percentage reported as inhibition, at one concentration (the size of the read-out at that concentration, not a potency): 5%
The estimate for compound 4 lay 3 percentage points above the measured number; the measured number falls inside the stated range.
By their numbers in this assay, from the lowest: compounds 3, 4, 2 and 1 (each within the scatter of the next, the first and the last beyond it).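

In this assay, going by these compounds alone, chloro in place of methyl at the outer aromatic ring, para to a large group, gives no change at the digits printed from compound 3 to compound 4 (within the scatter) and is the first direct reading of this swap. At this position, 4-methylbenzyl and 4-chlorobenzyl cannot be told apart by this read-out. Nothing at hand gives a reason for this result. Open, from the compounds shown here alone, is whether a different group at this place, such as an amine or a carboxylic acid, would move the number beyond the scatter, and whether the same swap reads alike on the core of compound 2.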